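This account rests on a few compounds, and the source may have more. Where it says the series, first, only, none or still open, it means among the compounds named here.

Measured compounds:
Compound 1, `CCn1c(C(=O)N[C@@H](C)CO)ccc1C(CC)(CC)c1ccc(OCS(=O)(=O)c2ccccc2)c(C)c1`, 10800 nM
Compound 2, `CCn1c(C(=O)NCCO)ccc1C(CC)(CC)c1ccc(OCS(=O)(=O)c2ccccc2)c(C)c1`, 15500 nM
Compound 3, `CCn1c(C(=O)NC2(CO)CC2)ccc1C(CC)(CC)c1ccc(OCS(=O)(=O)c2ccccc2)c(C)c1`, 28800 nM

In a functional assay on MCF7 cells (Homo sapiens) for antiproliferative activity, read by MTT assay, with a stated time of 24 h (on this read-out lower numbers stand for stronger inhibition and higher numbers for weaker inhibition), compound 1 gives the lowest of the three numbers; the step of a 1.4-fold higher number from compound 1 to compound 2 (0.16 log units; within the scatter) is within the scatter, while a 2.7-fold higher number from compound 1 to compound 3 (0.43 log units; beyond the scatter) is modest and beyond it. Compound 4, `CCn1c(C(=O)N[C@@H](C)C(=O)O)ccc1C(CC)(CC)c1ccc(OCS(=O)(=O)c2ccccc2)c(C)c1`, differs from compound 1 by carboxy in place of hydroxymethyl on a saturated chain carbon bound to an amide-type nitrogen and a saturated chain carbon. For the measured compounds named here, no measured step replaces hydroxymethyl with carboxy; the steps that bear on it, a 1.4-fold higher number from compound 1 to compound 2 (0.16 log units; within the scatter) and a 1.9-fold higher number from compound 2 to compound 3 (0.27 log units; within the scatter), all alter the group on the amide-type nitrogen and all gave higher numbers than compound 1, at most modestly. Compound 4 is therefore expected to give a somewhat higher number, a 2.0-fold higher number from compound 1 to compound 4 (0.31 log units; beyond the scatter), as the change reaches beyond what the measured variations cover. The estimate for compound 4 in this assay is 22000 nM, with a range from 8000 nM to 60000 nM.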

Compound 4, half-maximal inhibitory concentration: 35500 nM
The estimate for compound 4 lay 1.6-fold (0.21 log units) below the measured number; measured number inside the range.
By their numbers in this assay, from the lowest: compounds 1, 2, 3 and 4 (each within the scatter of the next, the first and the last beyond it).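

In this assay, for the compounds shown here, the earlier compounds varied only the group on the amide-type nitrogen while keeping its hydroxyl, whereas replacing hydroxymethyl with carboxy on the saturated chain carbon gives a 3.3-fold higher number from compound 1 to compound 4 (0.52 log units; beyond the scatter). The 1-carboxyethyl group also gives a 2.3-fold higher number from compound 2 to compound 4 (0.36 log units; beyond the scatter), a modest step of the same kind, while a 1.2-fold higher number from compound 3 to compound 4 (0.09 log units; within the scatter) leaves compound 4 and compound 3 undistinguished. Nothing available explains these steps. From the compounds shown here alone, whether a methyl ester or a primary amide in place of carboxy would stay close to compound 1 remains open, as does the effect of a longer chain carrying the carboxy group.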